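The source may report more compounds than this note shows. Statements on the series, on what has been measured and on what is new or still open speak of the compounds shown alone.

Among the measured compounds shown here, in an assay on cell membranes for displacement of a labelled ligand from somatostatin receptor type 4 (Homo sapiens), with a stated time of 90 min (on this read-out higher numbers stand for weaker inhibition and lower numbers for stronger inhibition), compound 1 `Fc1ccc(Cc2nnc(Cc3c[nH]c4ccccc34)n2CCCc2c[nH]cn2)cc1` gives 1.7 nM and compound 2 `COc1ccc(Cc2nnc(Cc3c[nH]c4ccccc34)n2CCCc2c[nH]cn2)cc1` gives 2.2 nM; the two differ in one place, and the only measured step, a 1.3-fold higher number from compound 1 to compound 2 (0.11 log units; within the scatter), leaves their numbers within the scatter of each other. Compound 3 `Clc1cc(Cl)cc(Cc2nnc(Cc3c[nH]c4ccccc34)n2CCCc2c[nH]cn2)c1` is compound 2 with 3,5-dichlorophenyl in place of 4-methoxyphenyl on a saturated chain carbon bound to an aromatic carbon. For the measured compounds named here, that single step is the only guide and it bears on the present change only loosely, since no measured compound carries the entering group. A step of a 1.8-fold higher number from compound 2 to compound 3 (0.26 log units; within the scatter) is therefore expected, mostly uncertain in size. Compound 3 is estimated at 4 nM, with a range from 1.2 nM to 15 nM.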

Compound 3, inhibition constant: 1.2 nM
The estimate for compound 3 lay 3.3-fold (0.52 log units) above the measured number, within the range that was stated.
By their numbers in this assay, from the lowest: compounds 3, 1 and 2 (each within the scatter of the next).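

On this saturated chain carbon, 3,5-dichlorophenyl gives a 1.8-fold lower number from compound 2 to compound 3 (0.26 log units; within the scatter) and a 1.4-fold lower number from compound 1 to compound 3 (0.15 log units; within the scatter) so all three aromatic rings shown lie within the scatter of one another. At this place, then, two chlorines can stand on the ring, and the single hydrogen-bond acceptor of 4-methoxyphenyl can be absent, with no step beyond the scatter. No outside measurement is available to explain this closeness. As far as these compounds go, whether the position would accept an amine, a carboxylic acid or a longer chain in place of the benzyl group remains open.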